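Aryl replacement on the five-membered ring: compound 3 to compound 4

The compounds below may be only part of what the source reports. "The series", "measured", "known", "first", "only" and "open" are said of these compounds alone.

The shared core carries a variable group on an aromatic carbon of a five-membered aromatic ring with 3 nitrogen. In an ADME assay on HFF cells (Homo sapiens) for cytotoxicity, read by MTT assay, with a stated time of 72 h (a higher number here means a weaker inhibitor, a lower number a stronger inhibitor), compound 1 `CCCCc1cn(C[C@H](O)[C@H]2OC(=O)C(OCc3ccccc3)=C2OCc2ccccc2)nn1` gives 26300 nM. Compound 2 `COc1ccccc1-c1cn(C[C@H](O)[C@H]2OC(=O)C(OCc3ccccc3)=C2OCc2ccccc2)nn1` gives 50 nM in this assay, so that a 530-fold lower number from compound 1 to compound 2 (2.72 log units; beyond the scatter). For compound 3 `Cc1ccc(-c2cn(C[C@H](O)[C@H]3OC(=O)C(OCc4ccccc4)=C3OCc3ccccc3)nn2)cc1` the assay reports only a limit, > 100000 nM. Compound 3 therefore stands at the limit of > 100000 nM in this assay, at which 1 of the 3 values shown sits, and both steps into it are bounded: an at least 3.8-fold higher number from compound 1 to compound 3 (0.58 log units; beyond the scatter) and an at least 2000-fold higher number from compound 2 to compound 3 (3.30 log units; beyond the scatter).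

Compound 4 `O=C1O[C@H]([C@@H](O)Cn2cc(-c3cc(F)cc(F)c3)nn2)C(OCc2ccccc2)=C1OCc1ccccc1` is not yet measured. It differs from compound 3 in one place: 3,5-difluorophenyl in place of 4-methylphenyl on an aromatic carbon. The measured steps that bear on this change are an at least 3.8-fold higher number from compound 1 to compound 3 (0.58 log units; beyond the scatter) and an at least 2000-fold higher number from compound 2 to compound 3 (3.30 log units; beyond the scatter); both show that the group on this carbon moves the number over a wide span, and the 2-methoxyphenyl of compound 2 and the 4-methylphenyl of compound 3 sit at opposite ends of that span. Since compound 3 itself is only a limit, the step to compound 4 can only be downward or none beyond the scatter. A modest downward step is expected, an at least 3.3-fold lower number from compound 3 to compound 4 (0.52 log units; beyond the scatter). Compound 4 is expected at 30000 nM, between 3000 nM and 100000 nM, with a real chance that only a limit is reported again.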

Compound 4, half-maximal inhibitory concentration: > 100000 nM
Compound 4: a limit, no number; the forecaster's own chance of this, stated with the estimate: 40%; middle value at least 3.3-fold (0.52 log units) from the limit.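

In this assay compound 4 sits at a limit, not at a number, and so does compound 3: the limit of > 100000 nM in this assay, at which 2 of the 4 values shown sit. The step between these two compounds therefore cannot be read, nor can it be said whether 3,5-difluorophenyl and 4-methylphenyl differ on this carbon. What the new result adds is that the low number of the 2-methoxyphenyl group now stands apart from a second substituted phenyl group, with an at least 2000-fold higher number from compound 2 to compound 4 (3.30 log units; beyond the scatter), and that the butyl group also gives a lower number than this second aryl group, with an at least 3.8-fold higher number from compound 1 to compound 4 (0.58 log units; beyond the scatter); among the three aryl groups shown, only the 2-methoxyphenyl of compound 2 goes against a high number.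

Still open, from the compounds shown here alone, is whether the low number of compound 2 is tied to the methoxy group itself, which an unsubstituted phenyl, a hydroxyphenyl or an aminophenyl on this carbon would help to settle. How the number moves along alkyl groups also remains open, since butyl is the only chain shown, and a longer chain or a chain ending in an amine would extend that side of the series.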